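This account rests on a few compounds, and the source may have more. Where it says the series, first, only, none or still open, it means among the compounds named here.

Working notes on the series. Compound 1 `Cn1ncc(Cl)c1-c1cc(C(=O)N[C@@H]2CN[C@H](CCn3cncn3)C[C@H]2c2ccc(Cl)c(Cl)c2)oc1Cl` has been measured in a functional assay on OVCAR-8 cells (Homo sapiens) for antiproliferative activity (on this read-out higher numbers stand for weaker inhibition and lower numbers for stronger inhibition), where compound 1 gives 1560 nM. Within the three numbers at hand, compound 1 sits at the upper edge, yet neither of the other two stands apart from it: compound 3 `Cn1ncc(Cl)c1-c1cc(C(=O)N[C@H]2CNCC[C@@H]2c2ccc(C(F)(F)F)cc2)oc1Cl` gives 900 nM, and compound 2 `CNC(=O)C[C@@H]1C[C@@H](c2ccc(F)c(F)c2)[C@H](NC(=O)c2cc(-c3c(Cl)cnn3C)c(Cl)o2)CN1` gives 800 nM, both within the usual scatter of the value for compound 1. Among the measured compounds shown here, no ordering among the three is therefore claimed, and no step between any two of them has been worked out.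

Compound 4 `COCC[C@@H]1C[C@@H](c2ccc(Cl)c(Cl)c2)[C@H](NC(=O)c2cc(-c3c(Cl)cnn3C)c(Cl)o2)CN1` has not yet been measured. It derives from compound 1 by one change: methoxy in place of 1H-1,2,4-triazol-1-yl on a saturated chain carbon, two bonds along the chain from a saturated ring carbon. Compound 2 carries a different small chain on the same carbon and compound 3 carries none there, and both of their values fall with that of compound 1 inside the scatter, so the chain on this carbon has so far not moved the read-out in a way that can be separated from noise. The expected step from compound 1 to compound 4 is accordingly small, a 1.6-fold lower number from compound 1 to compound 4 (0.19 log units; within the scatter), leaning if anything toward a lower number but not clearly beyond the scatter. For compound 4 the estimated value in this assay is 1000 nM, with a range from 400 nM to 2500 nM.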

Compound 4, half-maximal inhibitory concentration: 1060 nM
For compound 4 the middle estimate is 1.1-fold (0.03 log units) below the measured one; measured number inside the range.
By their numbers in this assay, from the lowest: compounds 2, 3, 4 and 1 (each within the scatter of the next).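

Working notes, continued. In this assay, among the compounds shown here, the step of a 1.5-fold lower number from compound 1 to compound 4 (0.17 log units; within the scatter) is the first direct reading at this position, and it shows that the two groups are not separated by this read-out. The exchange removes a five-membered aromatic ring with 3 hydrogen-bond acceptors and puts methoxy, with no ring and 1 hydrogen-bond acceptor, in its place, so neither the ring nor the larger heavy-atom count is needed to stay within the scatter of compound 1. No supporting data bear on why the two groups read alike.

Going by these compounds, whether a charged end on this chain, such as a primary amine or a carboxylic acid, would stay within the scatter remains open. So does the effect of a longer chain carrying methoxy at its end.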